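The compounds below may be only part of what the source reports. "The series", "measured", "known", "first", "only" and "open" are said of these compounds alone.

Measured so far:
Compound 1 `O=S(=O)(/C=C/c1ccc(F)cc1F)Cc1ccc(Nc2ncnc3ccccc23)cc1` — in a functional assay on PC-3 cells (Homo sapiens) (a higher number here means a weaker inhibitor of growth, a lower number a stronger inhibitor of growth), compound 1 reaches only the limit > 100000 nM.
Compound 2 `O=S(=O)(/C=C/c1ccc(F)cc1Cl)Cc1ccc(Nc2ncnc3ccccc23)cc1` — in this assay compound 2 gives 100000 nM.
Compound 3 `O=S(=O)(/C=C/c1ccc(F)cc1Cl)Cc1ccc(Nc2ncnc3cc(Cl)ccc23)cc1` — in this assay compound 3 gives 73000 nM.

The two cores differ as follows: chloro in place of hydrogen on an aromatic carbon. That step is a 1.4-fold lower number from compound 2 to compound 3 (0.14 log units; within the scatter).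

Compound 4 `O=S(=O)(/C=C/c1ccc(F)cc1F)Cc1ccc(Nc2ncnc3cc(Cl)ccc23)cc1` is not yet measured in this assay. It differs from compound 3 thus: fluoro in place of chloro on an aromatic carbon. The same change has already been made once, from compound 2 to compound 1: fluoro in place of chloro on an aromatic carbon. Its size there is a number no lower from compound 2 to compound 1 (the limit leaves the size open); the size cannot be read because of the limit of > 100000 nM in this assay, at which 1 of the 3 values shown sits.

For compound 4 the same change is expected to behave as it did between compound 2 and compound 1, so the number is expected to be no lower than that of compound 3, which gave 73000 nM. The expected step is a 1.5-fold higher number from compound 3 to compound 4 (0.18 log units; within the scatter). Compound 4 is therefore estimated at 110000 nM, with a range from 60000 nM to 250000 nM, and a fair chance that only a limit is reported.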

Compound 4, concentration for 50% growth inhibition: > 100000 nM
Compound 4: no number, only a limit (the forecaster's own chance of this, stated with the estimate: 55%); the middle value lies beyond the limit too.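

Going from the 2-chloro-4-fluorophenyl to the 2,4-difluorophenyl group on the chlorinated core gives, in this assay, an at least 1.3-fold higher number from compound 3 to compound 4 (0.13 log units; that floor lies within the scatter). This is only a floor, and it does not establish a real change on this core, so the result fits the earlier step without showing that the change carries over with the same size: the same change on two cores in this assay, a number no lower (the limit leaves the size open) from compound 2 to compound 1 and an at least 1.3-fold higher number (0.13 log units; that floor lies within the scatter) from compound 3 to compound 4; the limit leaves it open whether they differ No size can be transferred from one core to the other, and the step between the two difluorophenyl compounds cannot be read either, because both of its values are limits: the limit of > 100000 nM in this assay, at which 2 of the 4 values shown sit.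

The compounds shown leave open how large the fluoro-for-chloro step is when both partners give numbers rather than limits. They also leave open whether a methoxy or nitrile group in place of that chloro, or an amine on the shared core, would bring growth inhibition into a range where such steps can be read.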